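A few compounds are considered here, and "the series" means these few. Any claim that something is new, unique, unknown or untested is made for them only; others in the source may bear on it.

Working notes on the hydroxy-oxo amide series

The shared core carries a secondary amide whose nitrogen substituent varies. Compound 1 `O=C(NC1CCN(Cc2ccccc2)CC1)c1c(O)c2cccnc2n(-c2ccccc2)c1=O` bears a benzyl-piperidinyl group on that nitrogen; compound 2 `O=C(Nc1ccc(Cl)cc1)c1c(O)c2cccnc2n(-c2ccccc2)c1=O` a 4-chlorophenyl; compound 3 `O=C(Nc1ccc([N+](=O)[O-])cc1)c1c(O)c2cccnc2n(-c2ccccc2)c1=O` a 4-nitrophenyl. In a functional assay on the whole organism for inhibition, with Rattus norvegicus as the target, read by cytopathic effect and paw edema, at a dose of 100 mg/kg by the oral route (a lower number here means less inhibition, a higher number more inhibition at the dose given (going by the name of the read-out)), compound 1 gives 1.2%, compound 2 gives 2.5% and compound 3 gives -25.8%. Going by the values given here, the only single-point step measured so far, a number 28.3 percentage points lower from compound 2 to compound 3 (beyond the scatter), exchanges nitro for chloro on the aromatic carbon. Compound 3 therefore stands lowest of the three numbers, beyond the scatter from both compound 1 and compound 2.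

Compound 4 `O=C(NCc1cccnc1)c1c(O)c2cccnc2n(-c2ccccc2)c1=O` is the next member. Relative to compound 3 it differs by (pyridin-3-yl)methyl in place of 4-nitrophenyl on an amide-type nitrogen. Among the compounds with values here, no measured step covers an aryl-to-alkyl exchange on the amide nitrogen; the step from compound 2 to compound 3 concerns two aryl groups and bears only loosely. Compound 1, the one non-aryl amide, gives a number near zero, so compound 4 is expected to return toward that region, with an estimated step of a number 25.8 percentage points higher from compound 3 to compound 4 (beyond the scatter) and an estimate of 0%, between -20% and 20%, in this assay.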

Compound 4, a percentage reported as inhibition, in the whole organism at one dose (the size of the read-out at that dose, not a potency): 14.7%
Beside the measured number, compound 4's estimate is 14.7 percentage points below it; the range from low to high includes it.
By their numbers in this assay, from the lowest: compound 3; then compounds 1 and 2 (each within the scatter of the next); then compound 4.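

In this assay, the amide-type nitrogen now shows a step upward as well as downward: replacing an aryl group with (pyridin-3-yl)methyl gives a number 40.5 percentage points higher from compound 3 to compound 4 (beyond the scatter) and a number 12.2 percentage points higher from compound 2 to compound 4 (beyond the scatter). Both steps point the same way from different aryl starting points, so the rise at this position does not depend on the 4-nitrophenyl group alone, although the step from the nitro compound is the larger. Nothing available here accounts for either step.

Still open, as far as these compounds go, is whether the rise goes with the pyridin-3-yl ring or with the methyl link that joins it to the amide-type nitrogen, a question that a plain benzyl group there would help separate. Also open, from the compounds shown here alone, is how a longer chain, such as 2-(pyridin-3-yl)ethyl, or a carboxylic acid on that chain would read in this assay.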